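Sulfanyl to methylated methylene on the benzimidazole linker

This account rests on a few compounds, and the source may have more. Where it says the series, first, only, none or still open, it means among the compounds named here.

Compound 3 `O=C(Nc1ccccc1-c1ccccc1)[C@@H]1CCCN1C(=O)CSc1nc2ccccc2[nH]1` gives 10 nM in an assay on CHO cells for displacement of a labelled ligand from Orexin/Hypocretin receptor type 1 (Homo sapiens) (a lower number here means a stronger inhibitor, a higher number a weaker inhibitor), the second highest of the three numbers. Compound 1 `Cc1ccc2[nH]c(SCC(=O)N3CCC[C@H]3C(=O)Nc3ccccc3-n3cccc3)nc2c1` gives 3 nM in this assay, while compound 2 `COc1ccccc1-c1ccccc1NC(=O)[C@@H]1CCCN1C(=O)CCc1nc2ccccc2[nH]1` gives 86 nM; compound 2 differs from compound 3 in more than one place, so this gap is only suggestive. Compound 4 `Cn1c(CCC(=O)N2CCC[C@H]2C(=O)Nc2ccccc2-c2ccccc2)nc2ccccc21` carries (1-methyl-1H-benzimidazol-2-yl)methyl in place of (1H-benzimidazol-2-yl)sulfanyl on a saturated chain carbon bound to a carbonyl carbon. Among the compounds with values here, no single-point step exists for this change. A weakening step is nevertheless expected, because compound 2 with its 86 nM lies beyond the scatter on the weaker side of compound 3 and also carries a chain in place of the sulfanyl link: a 6.0-fold higher number from compound 3 to compound 4 (0.78 log units; beyond the scatter). Compound 4 is therefore estimated at 60 nM, with a range from 20 nM to 200 nM.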

Compound 4, inhibition constant: 15 nM
Estimate against measurement, compound 4: 4.0-fold (0.60 log units) above, outside the stated range (below it).
By their numbers in this assay, from the lowest: compound 1; then compounds 3 and 4 (each within the scatter of the next); then compound 2.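

In this assay, the exchange gives a 1.5-fold higher number from compound 3 to compound 4 (0.18 log units; within the scatter), so the sulfur link and the ring hydrogen-bond donor of compound 3 are not needed at this place for binding in the low nanomolar range. The gain of the methyl group on the ring nitrogen and the loss of sulfur arrive together in this single exchange, so their separate contributions cannot be read from it.

Still open, on these data alone, is whether an ether oxygen or an amine nitrogen in the link, or a longer chain, would read the same. Nothing available explains why compound 3 and compound 4 read alike.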